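The source may report more compounds than this note shows. Statements on the series, on what has been measured and on what is new or still open speak of the compounds shown alone.

Measured compounds:
- compound 1, `O=Cc1ccc(-c2cn3ccnc3c(-c3ccc4ncn(C5CCCCC5)c4c3)n2)cc1`: 82.5%
- compound 2, `O=Cc1ccc(-c2cn3ccnc3c(-c3ccc4ncn(Cc5ccccc5)c4c3)n2)cc1`: 82.5%
- compound 3, `c1cn2cc(-c3ccc4c(c3)ncn4C3CCCCC3)nc(-c3ccc4ncn(C5CCCCC5)c4c3)c2n1`: 70.8%

All three were run in a functional assay on RPMI-8226 cells (Homo sapiens) for inhibition, read by sulforhodamine B assay, with a stated time of 48 h, tested at 10 uM; on this read-out higher numbers stand for more inhibition at the one concentration tested (going by the name of the read-out) and lower numbers for less inhibition. In this assay compound 1 gives 82.5% and compound 2 gives 82.5%. The two differ by one change, (benzyl in place of cyclohexyl on an aromatic nitrogen), and the step is no change at the digits printed from compound 1 to compound 2 (within the scatter). Compound 3 carries a different core from compound 1; the difference between the two cores is not broken down here. In this assay compound 3 gives 70.8%, which is the lowest of the three numbers, with both compound 1 and compound 2 lying beyond the scatter above it.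

Compound 4, `c1ccc(Cn2cnc3ccc(-c4nc(-c5ccc6c(c5)ncn6C5CCCCC5)cn5ccnc45)cc32)cc1`, is not yet measured. It differs from compound 3 by benzyl in place of cyclohexyl on an aromatic nitrogen. The place of the change is the same as for the step from compound 1 to compound 2, so this is the same change on the core of compound 3. From compound 3 to compound 4 the expected step in this assay is a number 0.8 percentage points lower from compound 3 to compound 4 (within the scatter), which rests on the earlier step being no change at the digits printed from compound 1 to compound 2 (within the scatter): the exchange of cyclohexyl for benzyl left the read-out unchanged on the core of compound 1, and the same is expected on the core of compound 3. Compound 4 is therefore expected to give about 70% in this assay, with a likely range from 58% to 82%. Whether the lower level of compound 3 relative to compound 1 carries over cannot be told from one pair.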

Compound 4, a percentage reported as inhibition, at one concentration (the size of the read-out at that concentration, not a potency): -41.2%
Beside the measured number, compound 4's estimate is 111.2 percentage points above it; measured number below the stated range.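

In this assay, benzyl in place of cyclohexyl on an aromatic nitrogen gives no change at the digits printed from compound 1 to compound 2 (within the scatter) on the first core, but the same exchange gives a number 112 percentage points lower from compound 3 to compound 4 (beyond the scatter) on the second. Going by these compounds alone, the effect of this change therefore does not carry from one core to the other, and a flat result on one core gives no safe guide to the result on the other: the same change on two cores in this assay, no change at the digits printed (within the scatter) from compound 1 to compound 2 and a number 112 percentage points lower (beyond the scatter) from compound 3 to compound 4, 112 percentage points apart, beyond the scatter of two such steps This rests on only two matched pairs at a single concentration, and it does not show which difference between the cores goes with the large step, why the step arises, or how the change would behave on any third core.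

The compounds shown leave open whether the large step on the core of compound 3 belongs to benzyl as such or would also appear with other groups on the same nitrogen, such as methyl, a longer chain ending in phenyl, or a chain ending in an amine or a carboxylic acid. They also leave open whether the same groups would stay as flat on the core of compound 1 as benzyl and cyclohexyl do.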